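One more fluoro on the aromatic ring

The source may hold more compounds than are shown below. What is called first, only, known or untested is meant among the compounds shown, and "the series" means these compounds.

Values so far in a functional assay (aorta) for inhibition, with Rattus norvegicus as the target; a lower number here means that less compound is needed, a higher number that more compound is needed for the effect
Compound 1 (`O=C1C(Nc2cccc(F)c2)=CC(=O)c2ncccc21`) gives 805 nM
Compound 2 (`O=C1C(Nc2ccc(F)c(F)c2)=CC(=O)c2ncccc21`) gives 251 nM

Compound 2 has the lower number of the two measured compounds. Compound 3 (`O=C1C(Nc2ccc(F)c(F)c2F)=CC(=O)c2ncccc21`) differs from it by one further change on the aromatic ring (fluoro in place of hydrogen on an aromatic carbon), with fluoro in place of hydrogen on an aromatic carbon. For the measured compounds named here, only one measured step is of the same kind (a 3.2-fold lower number from compound 1 to compound 2 (0.51 log units; beyond the scatter)), and the new fluoro takes a different place. One step is thin evidence, so a smaller fall is expected in this assay, with a rise not excluded. The expected size is modest (a 1.6-fold lower number from compound 2 to compound 3 (0.20 log units; within the scatter)) and remains an estimate. For compound 3 the estimated value is 160 nM with an expected range from 50 nM to 500 nM in this measurement.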

Compound 3, half-maximal effective concentration: 937 nM
Beside the measured number, compound 3's estimate is 5.9-fold (0.77 log units) below it; measured number outside the range, above it.
By their numbers in this assay, from the lowest: compound 2; then compounds 1 and 3 (each within the scatter of the next).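

In this assay the swap of hydrogen for fluoro does not always lower the number. At this place on the aromatic ring, ortho to a fluoro group and ortho to a large group, the swap gives a 3.7-fold higher number from compound 2 to compound 3 (0.57 log units; beyond the scatter) and so runs opposite in direction to a 3.2-fold lower number from compound 1 to compound 2 (0.51 log units; beyond the scatter) at another place. Nothing available here explains this reversal.

Still open, going by these compounds, is whether the higher number belongs to fluoro alone or would also follow another group at this place, such as a chloro, methyl or methoxy group.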